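Replacing 1H-pyrazol-4-yl with quinolin-3-yl on a shared core

The source may report more compounds than this note shows. Statements on the series, on what has been measured and on what is new or still open speak of the compounds shown alone.

In an ADME assay on MDCKII-LE cells (Canis lupus familiaris) for permeability (a lower number here means that the compound crosses the layer more slowly, a higher number that the compound crosses the layer faster), compound 1 (`COc1ccc(-c2cc3c(C)nc(N)nc3n([C@H]3CC[C@@H](OCO)CC3)c2=O)cn1`) gives 19.3 10^-6 cm/s and compound 2 (`COc1ncc(-c2cc3c(C)nc(N)nc3n([C@H]3CC[C@@H](OCO)CC3)c2=O)cc1F`) gives 17.9 10^-6 cm/s while compound 3 (`Cc1nc(N)nc2c1cc(-c1cn[nH]c1)c(=O)n2[C@H]1CC[C@@H](OCO)CC1`) gives 12.6 10^-6 cm/s on the same scale. Compound 3 therefore stands within the usual scatter of both other compounds. Compound 4 (`Cc1nc(N)nc2c1cc(-c1cnc3ccccc3c1)c(=O)n2[C@H]1CC[C@@H](OCO)CC1`) differs from compound 3 in one place, with quinolin-3-yl in place of 1H-pyrazol-4-yl on an aromatic carbon. The most relevant evidence comes from changes at that same carbon. Putting 1H-pyrazol-4-yl there in place of the groups in the two other compounds gave a 1.5-fold lower number from compound 1 to compound 3 (0.19 log units; within the scatter) and a 1.4-fold lower number from compound 2 to compound 3 (0.15 log units; within the scatter) and neither step leaves the scatter. Among the compounds with values here, no measured compound carries quinolin-3-yl, so this is indirect evidence. Nothing here points to a clear shift in this assay for compound 4. The expected change is a 1.2-fold higher number from compound 3 to compound 4 (0.08 log units; within the scatter) and no step beyond the scatter is anticipated. For compound 4 the estimated value is 15 10^-6 cm/s with an expected range from 8 10^-6 cm/s to 25 10^-6 cm/s in this measurement.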

Compound 4, apparent permeability: 41.6 10^-6 cm/s
Beside the measured number, compound 4's estimate is 2.8-fold (0.44 log units) below it; the measured number lies above the stated range.
By their numbers in this assay, from the lowest: compounds 3, 2 and 1 (each within the scatter of the next); then compound 4.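

At this aromatic carbon in this assay, swaps among the earlier groups stayed within the scatter, but quinolin-3-yl moves the number beyond it against all three other compounds: a 3.3-fold higher number from compound 3 to compound 4 (0.52 log units; beyond the scatter) and a 2.3-fold higher number from compound 2 to compound 4 (0.37 log units; beyond the scatter) and a 2.2-fold higher number from compound 1 to compound 4 (0.33 log units; beyond the scatter). So this position can respond to the group placed on it, and compound 4 stands apart from compounds that carry either a pyrazole or a substituted pyridine there. No measured property of these groups is available to explain the rise.

The compounds shown leave open whether the second aromatic ring of quinolin-3-yl is what matters, or whether its attachment through a nitrogen-containing ring matters too. As far as these compounds go, a plain phenyl or naphthalen-2-yl group at this carbon would separate those two readings, and how an amine or a carboxylic acid there would compare also remains open.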